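The source may report more compounds than this note shows. Statements on the series, on what has been measured and on what is new or still open speak of the compounds shown alone.

Compound 1 `CCN(CC)Cc1ccc(S(=O)(=O)NCc2ccc(CNC(=O)c3ccc(F)cc3)cc2)cc1` gives 1 nM in an assay on MDA-MB-231 cells for binding affinity to C-X-C chemokine receptor type 4 (Homo sapiens), read by fluorescence and microscopy, with stated times of 10 min and 30 min; a lower number here means that less compound is needed, a higher number that more compound is needed for the effect. Compound 2 `O=C(NCc1ccc(CNS(=O)(=O)c2cccnc2)cc1)c1ccc(F)cc1` gives 1000 nM. Compound 3 `Cc1ccc(S(=O)(=O)NCc2ccc(CNC(=O)c3ccc(F)cn3)cc2)cc1` gives 1000 nM.

On these numbers compound 2 stands level with compound 3 at the digits shown, and together they carry the highest values of the three; the gap between compound 2 and compound 1 is beyond the scatter, with compound 1 the lower of the pair. Compound 4 `O=C(NCc1ccc(CNS(=O)(=O)c2ccc([N+](=O)[O-])cc2)cc1)c1ccc(F)cc1` has not been measured in this assay. It differs from compound 2 in one place: 4-nitrophenyl in place of pyridin-3-yl on a sulfonyl sulfur. The values of compound 2 and compound 3 show that two different rings on the sulfonyl sulfur land at the same number, so for compound 4 no step beyond the scatter is expected, and no change at the digits printed from compound 2 to compound 4 (within the scatter) is the estimated change. Compound 4 is therefore expected to give about 1000 nM, within a range from 300 nM to 3000 nM.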

Compound 4, effective concentration (reported as EC, without a stated level of effect): 1000 nM
Beside the measured number, compound 4's estimate shows no gap at the digits printed, and the stated range covers the measured number.
By their numbers in this assay, from the lowest: compound 1; then compounds 2, 3 and 4 (each within the scatter of the next).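

The change to 4-nitrophenyl in place of pyridin-3-yl on a sulfonyl sulfur gives no change at the digits printed from compound 2 to compound 4 (within the scatter) in this assay, although the entering group carries more heavy atoms. Nitro in place of (diethylamino)methyl on an aromatic carbon, by contrast, gives a 1000-fold higher number from compound 1 to compound 4 (3.00 log units; beyond the scatter), the first single-place step here that lies beyond the scatter. Nothing available explains either step. The compounds shown leave open whether another amine, such as a pyrrolidinylmethyl or aminomethyl group, or a carboxylic acid in that place would keep the low number of compound 1.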